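The source may hold more compounds than are shown below. What is called first, only, known or untested is meant among the compounds shown, and "the series" means these compounds.

Compound 1: `COCC(=O)Nc1ccc(Oc2cccc(OC)c2)cc1` gives 5.9 nM
Compound 2: `CCC(=O)Nc1ccc(Nc2cccc(OC)c2)cc1` gives 1.8 nM
Compound 3: `COc1cccc(N(C)c2ccc(NC(C)=O)cc2)c1` gives 0.23 nM

These three compounds were measured in an assay on isolated protein for binding affinity to melatonin receptor type 1B (Homo sapiens); a higher number here means a weaker inhibitor, a lower number a stronger inhibitor. Compound 1 gives 5.9 nM and compound 2 gives 1.8 nM, while compound 3 gives 0.23 nM, the lowest of the three numbers and therefore the strongest inhibitor of the group. Its distance to compound 2 and to compound 1 is in each case beyond the scatter of repeated measurements.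

Compound 4 is `CCC(=O)Nc1ccc(N(C)c2cccc(OC)c2)cc1`, not yet measured. It differs from compound 3 in one place: methyl in place of hydrogen on a saturated chain carbon bound to a carbonyl carbon. Put plainly, the acetamido group of compound 3 becomes a propanoylamino group, and everything else in the molecule stays as it is.

Among the compounds with values here, no pair among the measured compounds differs in only this way, so there is no measured step to lean on. Compound 2 already carries the propanoylamino group and gives 1.8 nM, but it also differs from compound 3 in another place, so its value shows nothing clean about this one change. Given that, the expected step is small: a change in this assay from compound 3 to compound 4 of a 1.2-fold lower number from compound 3 to compound 4 (0.06 log units; within the scatter), not clearly beyond the scatter in either direction. For compound 4 the estimated value in this assay is 0.2 nM, with a plausible range from 0.06 nM to 0.7 nM.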

Compound 4, inhibition constant: 0.17 nM
For compound 4 the middle estimate is 1.2-fold (0.07 log units) above the measured one; measured number inside the range.
By their numbers in this assay, from the lowest: compounds 4 and 3 (each within the scatter of the next); then compound 2; then compound 1.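

In this assay, methyl in place of hydrogen on a saturated chain carbon bound to a carbonyl carbon gives a 1.4-fold lower number from compound 3 to compound 4 (0.13 log units; within the scatter) and so leaves acetamido and propanoylamino indistinguishable in this series, a reading that needed a pair differing only in this way. Within the data shown here, the new structure also completes a second such pair, and methyl in place of hydrogen on a nitrogen on an aromatic ring gives an 11-fold lower number from compound 2 to compound 4 (1.02 log units; beyond the scatter) as a large step, so of the two single changes now readable, only the one on the nitrogen stands clear of the scatter. Nothing shown here gives a measured reason for either result.

The compounds shown leave open whether the chain tolerates more than this one added carbon, as a butanoyl group or a longer chain would test, and whether an ethyl group on the same nitrogen would keep the low number seen with methyl. As far as these compounds go, both steps also come from a single shared core carrying the methoxy group, so whether they hold with an oxygen in place of that nitrogen remains unknown.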